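This account rests on a few compounds, and the source may have more. Where it says the series, first, only, none or still open, it means among the compounds named here.

Compound 1 `Nc1nn(C(=O)Nc2ccc(Cc3ccccc3)cc2)c2ccccc12` gives 63900 nM in a functional assay on OVCAR-8 cells (Homo sapiens) for antiproliferative activity, read by sulforhodamine B assay, with a stated time of 48 h; on this read-out lower numbers stand for stronger inhibition of growth and higher numbers for weaker inhibition of growth. Compound 2 `Nc1nn(C(=O)Nc2ccc(Cc3ccccc3)cc2)c2ccc(Cl)cc12` gives only a limit of the assay in this assay, namely > 100000 nM.

Compound 2 therefore stands at the limit, and of the two values shown one sits there (the limit of > 100000 nM in this assay, at which 1 of the 2 values shown sits). Within the data shown here, the single measured step, an at least 1.5-fold higher number from compound 1 to compound 2 (0.19 log units; that floor lies within the scatter), runs from a number to that limit, and its floor lies within the usual scatter, so the true size of the step is open.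

Compound 3 `Nc1ccc2c(c1)c(N)nn2C(=O)Nc1ccc(Cc2ccccc2)cc1` differs from compound 2 by amino in place of chloro on an aromatic carbon. Among the measured compounds shown here, no measured step swaps chloro for amino at this position; the only step touching this carbon concerns chloro in place of hydrogen and, as noted, is bounded from below within the scatter. The expected step in this assay is therefore small and of uncertain direction, an at least 1.2-fold lower number from compound 2 to compound 3 (0.09 log units; that floor lies within the scatter), with a fair chance that only a limit is returned again. Compound 3 is estimated at 80000 nM in this assay, within 25000 nM to 250000 nM.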

Compound 3, concentration for total growth inhibition: > 100000 nM
Compound 3 gave a limit, no number; the forecaster's own chance of this, stated with the estimate: 40%; at least 1.2-fold (0.09 log units) between middle value and limit.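

Amino in place of hydrogen gives an at least 1.5-fold higher number from compound 1 to compound 3 (0.19 log units; that floor lies within the scatter) and so leaves the true size of that change open. The steps between compound 2 and compound 3 cannot be read, as each compound returns only a limit of the assay, and chloro and amino on this aromatic carbon therefore cannot be ranked. Two different replacements of hydrogen on this carbon now end without a number in this assay, where the earlier compounds showed only one: the limit of > 100000 nM in this assay, at which 2 of the 3 values shown sit.

Going by these compounds, whether a methoxy or a carboxylic acid on this aromatic carbon would return a number in this assay remains open. So does whether any replacement of the hydrogen of compound 1 here changes the read-out by more than the usual scatter.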